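The source may report more compounds than this note shows. Statements on the series, on what has been measured and on what is new or still open speak of the compounds shown alone.

Of the compounds shown here, three built on one shared core have been tested in a functional assay on SW-620 cells (Homo sapiens) for cytotoxicity, read by sulforhodamine B assay, with a stated time of 48 h, tested at 100 uM; on this read-out higher numbers stand for a weaker effect at the one concentration tested and lower numbers for a stronger effect. Compound 1 `COc1ccc(-c2cc(/C=C/C(=O)c3ccc(N)cc3)[nH]n2)cc1` gives -58%. Compound 2 `COc1cc(-c2cc(/C=C/C(=O)c3ccc(N)cc3)[nH]n2)cc(OC)c1OC` gives -40%, the highest of the three numbers, and since its steps to both other compounds lie beyond the scatter it shows the weakest effect of the set on this read-out. Compound 3 `COc1ccc(C(=O)/C=C/c2cc(-c3cc(OC)c(OC)c(OC)c3)n[nH]2)cc1OC` gives -67%. Among the measured compounds shown here, the only measured step between two compounds that differ in a single place is a number 27 percentage points lower from compound 2 to compound 3 (beyond the scatter), a swap of the group on a carbonyl carbon.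

Compound 4 `COc1ccc(-c2cc(/C=C/C(=O)c3ccc(N)cc3)[nH]n2)cc1OC` differs from compound 2 elsewhere: hydrogen in place of methoxy on an aromatic carbon. For the measured compounds named here, no measured step covers a change of this kind, so the step from compound 2 to compound 3 bears on it only loosely, showing that a single replacement can move the number by a modest amount. Going by the values given here, compound 1, which carries a single methoxy group in place of compound 2's three, gives a lower number than compound 2, though no step between those two has been computed. A modest fall is therefore expected, estimated as a number 10 percentage points lower from compound 2 to compound 4 (within the scatter). Compound 4 is expected to give about -50%, with a range from -70% to -30%.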

Compound 4, a percentage reported as activity, at one concentration (the size of the read-out at that concentration, not a potency): -53%
Estimate against measurement, compound 4: 3 percentage points above, and the stated range covers the measured number.
By their numbers in this assay, from the lowest: compounds 3, 1 and 4 (each within the scatter of the next, the first and the last beyond it); then compound 2.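

In this assay, the methoxy group that sits ortho to a methoxy group and meta to a large group can be replaced by hydrogen with a result that exceeds the usual scatter: a number 13 percentage points lower from compound 2 to compound 4 (beyond the scatter). Among the compounds shown here, this is the first measured single-place change on the methoxy-bearing aromatic ring, as the earlier step concerned the group on the carbonyl carbon. Adding a methoxy group to that ring from the other direction gives a number 5 percentage points higher from compound 1 to compound 4 (within the scatter), so among these three compounds, going from three methoxy groups to two changes the read-out clearly, while going from one to two gives no difference that can be told from scatter, and nothing available explains that contrast.

On these data alone, it remains open whether hydrogen is special at this position, or whether a hydroxyl group, a fluorine atom or a longer ethoxy chain there would give a number closer to that of compound 2 or of compound 4. As far as these compounds go, it is also open whether the same replacement would have a similar effect with the 3,4-dimethoxyphenyl group of compound 3 on the carbonyl carbon in place of 4-aminophenyl.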